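Nitro for methoxy: expected growth inhibition of compound 4

The source may hold more compounds than are shown below. What is called first, only, known or untested is meant among the compounds shown, and "the series" means these compounds.

Compound 1 `CC1=CC[C@H](C(C)(C)NC(=S)N/N=C/c2ccc(N(C)C)cc2)CC1`: in a functional assay on NCI-H460 cells (Homo sapiens) for inhibition, read by sulforhodamine B assay, with a stated time of 48 h (a higher number here means a weaker inhibitor of growth, a lower number a stronger inhibitor of growth), compound 1 gives > 100000 nM, a limit of the assay and not a number.
Compound 2 `CC1=CC[C@H](C(C)(C)NC(=S)N/N=C(\C)c2ccccc2)CC1`: in this assay compound 2 gives > 100000 nM, likewise a limit.
Compound 3 `COc1ccc(/C(C)=N/NC(=S)NC(C)(C)[C@H]2CC=C(C)CC2)cc1`: in this assay compound 3 gives > 100000 nM, again a limit.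

Compound 3 therefore stands nowhere in particular among the measured compounds: every value shown sits at the limit of > 100000 nM in this assay, at which 3 of the 3 values shown sit, and no ordering among compounds 1, 2 and 3 can be read. Going by the values given here, the only single-point step available, a step that the two limits leave unreadable from compound 2 to compound 3, cannot be sized because the limit of > 100000 nM in this assay, at which 3 of the 3 values shown sit, holds at both of its ends.

Compound 4 `CC1=CC[C@H](C(C)(C)NC(=S)N/N=C(\C)c2ccc([N+](=O)[O-])cc2)CC1` differs from compound 3 by nitro in place of methoxy on an aromatic carbon. Among the compounds with values here, no measured step bears on this exchange with a readable size; the exchange at the same aromatic carbon from compound 2 to compound 3 left both values at the limit. With nothing to suggest movement, the step from compound 3 to compound 4 is expected to be a number no higher from compound 3 to compound 4 (the limit leaves the size open), that is, none beyond the scatter, and compound 4 is most likely to be reported as a limit again. The estimate for compound 4 in this assay is 100000 nM, with a range from 30000 nM to 300000 nM.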

Compound 4, concentration for total growth inhibition: 83700 nM
Compound 4: the middle estimate sits 1.2-fold (0.08 log units) above what was measured; the measured number falls inside the stated range.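

In this assay, going by these compounds alone, compound 4 gives 83700 nM, the first number rather than a limit of the assay, so nitro on this aromatic carbon, para to a large group, gives the first readable value at this position. As far as these compounds go, only floors can be read for the steps that reach it, an at least 1.1-fold lower number from compound 3 to compound 4 (0.07 log units; that floor lies within the scatter) and an at least 1.1-fold lower number from compound 2 to compound 4 (0.07 log units; that floor lies within the scatter), so neither establishes a real gain, and the true sizes remain open. The remaining steps cannot be read, and the series still sits mostly at one end of the scale: the limit of > 100000 nM in this assay, at which 3 of the 4 values shown sit.

Open, from the compounds shown here alone, is whether a nitrile or a carboxylic acid on the same aromatic carbon would give a number clearly lower than that of compound 4. Also open, going by these compounds, is whether any group at this position can move the series well beyond the scatter.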